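Swapping hydrogen for (pyridin-2-yl)methyl on the amide nitrogen

This account rests on a few compounds, and the source may have more. Where it says the series, first, only, none or still open, it means among the compounds named here.

Compound 1 `CNC(=O)c1noc([C@H](CCCC2CCCCC2)CC(=O)NO)n1`: 28 nM
Compound 2 `O=C(C[C@@H](CCCC1CCCCC1)c1nc(C(=O)NCc2ccccc2)no1)NO`: 57 nM

In an assay on CHO cells for inhibition of bone morphogenetic protein 1 (Homo sapiens), read by fluorescence (on this read-out higher numbers stand for weaker inhibition and lower numbers for stronger inhibition), compound 1 stands lowest of the two numbers. Compound 2 is its nearest neighbour, reached by a 2.0-fold higher number from compound 1 to compound 2 (0.31 log units; beyond the scatter). Compound 3 `CN(Cc1ccccn1)C(=O)c1noc([C@H](CCCC2CCCCC2)CC(=O)NO)n1` differs from compound 1 by (pyridin-2-yl)methyl in place of hydrogen on an amide-type nitrogen. Among the measured compounds shown here, the only measured step at this amide is the one from compound 1 to compound 2, a modest weakening, and a change of similar size and direction is expected here. Compound 3 is therefore expected to give 60 nM, likely between 20 nM and 180 nM, which means an estimated 2.1-fold higher number from compound 1 to compound 3 (0.33 log units; beyond the scatter).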

Compound 3, half-maximal inhibitory concentration: 40 nM
Compound 3: the middle estimate sits 1.5-fold (0.18 log units) above what was measured; measured number inside the range.
By their numbers in this assay, from the lowest: compounds 1, 3 and 2 (each within the scatter of the next, the first and the last beyond it).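

In this assay, the amide nitrogen of compound 1 accepts (pyridin-2-yl)methyl with no change beyond the scatter (a 1.4-fold higher number from compound 1 to compound 3 (0.15 log units; within the scatter)). Methyl((pyridin-2-yl)methyl)amino in place of benzylamino on the carbonyl carbon likewise stays within the scatter (a 1.4-fold lower number from compound 2 to compound 3 (0.15 log units; within the scatter)), so this position tolerates a sizeable group here. No evidence is available to explain this tolerance.

As far as these compounds go, it remains open whether benzyl in place of (pyridin-2-yl)methyl in compound 3 would read the same. Also open, from the compounds shown here alone, is whether a carboxylic acid or an amine on the added ring would move the number beyond the scatter.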